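This account rests on a few compounds, and the source may have more. Where it says the series, first, only, none or still open, it means among the compounds named here.

Measured so far:
compound 1 `CCc1nc2c(OCc3ccccc3)cccn2c1N` gives 83%
compound 2 `CC(C)c1nc2c(OCc3ccccc3)cccn2c1N` gives 0%
compound 3 `Cc1nc2c(OCc3ccccc3)cccn2c1CN` gives 46%

In a functional assay on the whole organism with Rattus norvegicus as the target, at a dose of 40 mg/kg by the intraperitoneal route (a lower number here means less inhibition, a higher number more inhibition at the dose given (going by the name of the read-out)), compound 3 stands second highest of the three numbers: compound 1 is higher beyond the scatter, compound 2 lower beyond the scatter. Compound 4 `CC(=O)Nc1c(C)nc2c(OCc3ccccc3)cccn12` differs from compound 3 by acetamido in place of aminomethyl on an aromatic carbon. Going by the values given here, the only recorded step, a number 83 percentage points lower from compound 1 to compound 2 (beyond the scatter), concerns a different place on the shared core and bears on the present change only indirectly, showing that a small alteration can abolish the read-out. Among the compounds with values here, compound 1 and compound 3 differ in two places with no step recorded between them; their two values merely show the lower number for compound 3. Within the data shown here, with no step bearing directly on this change, the expected step of a number 21 percentage points lower from compound 3 to compound 4 (beyond the scatter) is a moderate fall with wide uncertainty. Compound 4 is expected to give 25%, in the range 0% to 65%.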

Compound 4, a percentage reported as inhibition, in the whole organism at one dose (the size of the read-out at that dose, not a potency): 93%
Estimate against measurement, compound 4: 68 percentage points below; measured number outside the range, above it.
By their numbers in this assay, from the lowest: compound 2; then compound 3; then compounds 1 and 4 (each within the scatter of the next).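

In this assay, acetamido in place of aminomethyl on this aromatic carbon of the five-membered ring gives a number 47 percentage points higher from compound 3 to compound 4 (beyond the scatter), so a group with more heavy atoms is accepted here without loss of the read-out. The hydrogen-bond donor and acceptor counts are the same for both groups, so those counts do not separate compound 3 from compound 4. No measurement available here accounts for the rise.

Still open, from the compounds shown here alone, is how a free amine on this carbon would compare with acetamido while the ring methyl group stays in place. Also open, going by these compounds, is whether a longer acyl chain, such as propionamido, would keep the read-out at this level.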